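A few compounds are considered here, and "the series" means these few. Any claim that something is new, unique, unknown or untested is made for them only; others in the source may bear on it.

Going by the values given here, in a functional assay (muscle tissue) with Cavia porcellus as the target (on this read-out lower numbers stand for an effect already at smaller amounts and higher numbers for an effect only at larger amounts of compound), compound 2 `COC(=O)C1=C(C)N=C(C)/C(=C(\O)OC)C1c1ccc(Cl)cc1` gives 8130 nM, the higher of the two numbers measured so far, while compound 1 `COC(=O)C1=C(C)N=C(C)/C(=C(\O)OC)C1c1cccc(OC)c1` gives 191 nM. Compound 3 `COC(=O)C1=C(C)N=C(C)/C(=C(\O)OC)C1c1cc(Cl)cc(Cl)c1` carries 3,5-dichlorophenyl in place of 4-chlorophenyl on a saturated ring carbon. Among the compounds with values here, one measured step bears on this change at the same ring carbon: a 43-fold higher number from compound 1 to compound 2 (1.63 log units; beyond the scatter), a large one, with 4-chlorophenyl entering in place of 3-methoxyphenyl. With 4-chlorophenyl now leaving, a moderate step towards a lower number is expected in this assay, smaller than that one, as 3-methoxyphenyl does not return. The estimated step is a 6.8-fold lower number from compound 2 to compound 3 (0.83 log units; beyond the scatter). For compound 3 the expected value is 1200 nM, within an estimated range from 200 nM to 7000 nM.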

Compound 3, half-maximal effective concentration: 93.3 nM
For compound 3 the middle estimate is 13-fold (1.11 log units) above the measured one, outside the stated range (below it).
By their numbers in this assay, from the lowest: compound 3; then compound 1; then compound 2.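

In this assay, a change on the saturated ring carbon that stays among chlorine-bearing phenyl groups proves as large as any seen here: 3,5-dichlorophenyl in place of 4-chlorophenyl gives an 87-fold lower number from compound 2 to compound 3 (1.94 log units; beyond the scatter) and so reverses the loss seen earlier. Against 3-methoxyphenyl the same group gives only a 2.0-fold lower number from compound 1 to compound 3 (0.31 log units; beyond the scatter) and thus shows that a chlorine-bearing phenyl group can match or pass the methoxy one, with 4-chlorophenyl alone standing apart. No evidence is available that explains these steps.

The compounds shown leave open whether the added chlorine or the changed placement of chlorine drives the step, since both change together. Going by these compounds, how an amine or a carboxylic acid on this phenyl ring would read out also remains open.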